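Chain extension from compound 3 to compound 4

The source may report more compounds than this note shows. Statements on the series, on what has been measured and on what is new or still open speak of the compounds shown alone.

Compound 1 `COc1ccc(NC(=S)Nc2nc(C(=O)NCc3ccccc3)cs2)cc1` gives 24600 nM
Compound 2 `COc1ccc(NC(=S)Nc2nc(C(=O)NCCCc3ccccc3)cs2)cc1` gives 63800 nM
Compound 3 `O=C(NCc1ccccc1)c1csc(NC(=S)Nc2ccc(Cl)cc2)n1` gives 56500 nM

All three values come from a functional assay on MCF7 cells (Homo sapiens) for antiproliferative activity, read by MTT assay, with a stated time of 72 h (on this read-out higher numbers stand for weaker inhibition and lower numbers for stronger inhibition), and are the only data so far. Compound 3 lies within the scatter of compound 2, and both numbers lie above that of compound 1. The chloro substituent alone accounts for the gap to compound 3 (a 2.3-fold higher number from compound 1 to compound 3 (0.36 log units; beyond the scatter)), but that step is a different change and only sets the starting point here.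

Compound 4 `O=C(NCCCc1ccccc1)c1csc(NC(=S)Nc2ccc(Cl)cc2)n1` carries one change from compound 3 (phenethyl in place of phenyl on a saturated chain carbon bound to an amide-type nitrogen), phenethyl in place of phenyl on a saturated chain carbon bound to an amide-type nitrogen. Cut one bond further out, this reads benzyl to 3-phenylpropyl. The same change has been measured once, on the methoxy compounds (a 2.6-fold higher number from compound 1 to compound 2 (0.41 log units; beyond the scatter)), and that step is modest but beyond the scatter. Within the data shown here, no measured pair yet tests it on a chloro compound, so its transfer is uncertain. A modest step of similar size towards a higher number is expected in this assay (a 2.3-fold higher number from compound 3 to compound 4 (0.36 log units; beyond the scatter)). Compound 4 is estimated at 130000 nM (expected range 55000 nM to 300000 nM).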

Compound 4, half-maximal inhibitory concentration: 45100 nM
For compound 4 the middle estimate is 2.9-fold (0.46 log units) above the measured one; the measured number lies below the stated range.
By their numbers in this assay, from the lowest: compounds 1, 4, 3 and 2 (each within the scatter of the next, the first and the last beyond it).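

In this assay, the same extension from benzyl to 3-phenylpropyl that raised the number on the methoxy compounds gives no change beyond the scatter on the chloro compounds, a 1.3-fold lower number from compound 3 to compound 4 (0.10 log units; within the scatter), so the outcome of this change depends on the core that carries it: the same change on two cores in this assay, a 2.6-fold higher number (0.41 log units; beyond the scatter) from compound 1 to compound 2 and a 1.3-fold lower number (0.10 log units; within the scatter) from compound 3 to compound 4, 3.2-fold (0.51 log units) apart, beyond the scatter of two such steps The reverse reading holds for the aromatic substituent, since chloro in place of methoxy gives a 1.4-fold lower number from compound 2 to compound 4 (0.15 log units; within the scatter) with the 3-phenylpropyl chain, against a 2.3-fold higher number from compound 1 to compound 3 (0.36 log units; beyond the scatter) with the benzyl group: the same change on two cores in this assay, a 2.3-fold higher number (0.36 log units; beyond the scatter) from compound 1 to compound 3 and a 1.4-fold lower number (0.15 log units; within the scatter) from compound 2 to compound 4, 3.2-fold (0.51 log units) apart, beyond the scatter of two such steps Across these four compounds the two changes therefore do not add up, and a step measured on one core cannot simply be carried over to the other.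

Open, from the compounds shown here alone, is whether a longer chain such as 4-phenylbutyl at this place follows the methoxy compounds, the chloro compounds or neither. Also open, going by these compounds, is whether the same dependence appears with a fluoro or a dimethylamino group in place of chloro or methoxy on the aromatic carbon.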